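Bromo for Methyl on an Aromatic Carbon of Compound 3

A few compounds are considered here, and "the series" means these few. Any claim that something is new, unique, unknown or untested is made for them only; others in the source may bear on it.

Three compounds were measured in a functional assay on HeLa cells (Homo sapiens) for inhibition, read by sulforhodamine B assay, with a stated time of 48 h; on this read-out lower numbers stand for stronger inhibition of growth and higher numbers for weaker inhibition of growth. Compound 1 `COC(=O)[C@@]1(C)CCC=C2[C@@H]1CC[C@@H](C)[C@]2(C)Cc1c[nH]c2ccc(F)cc12` gives 3700 nM in this assay. Compound 2 `COC(=O)[C@@]1(C)CC[C@@H]2C3=C1CC[C@@H](C)[C@]3(C)C[C@@H]1c3ccccc3N[C@H]21` gives 19000 nM, and compound 3 `COC(=O)[C@@]1(C)CC[C@@H]2C3=C1CC[C@@H](C)[C@]3(C)C[C@@H]1c3cccc(C)c3N[C@H]21` gives 22000 nM. Compound 3 thus carries the highest of the three numbers; its nearest neighbour is compound 2, whose value lies within the scatter of it, whereas compound 1 stands well apart, beyond the scatter.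

Compound 4 `COC(=O)[C@@]1(C)CC[C@@H]2C3=C1CC[C@@H](C)[C@]3(C)C[C@@H]1c3cccc(Br)c3N[C@H]21` has not yet been measured. It differs from compound 3 by bromo in place of methyl on an aromatic carbon. Going by the values given here, the only measured step at the same place is a 1.2-fold higher number from compound 2 to compound 3 (0.06 log units; within the scatter), which shows that adding methyl on this aromatic carbon left the number essentially unchanged. Among the compounds with values here, no measured pair here tells how bromo compares with methyl, so the expectation rests on that single step. Compound 4 is expected to behave much like compound 3, with no change beyond the scatter in this assay. The expected step is a 1.1-fold lower number from compound 3 to compound 4 (0.04 log units; within the scatter). Compound 4 is therefore estimated at 20000 nM, with a range from 8000 nM to 50000 nM.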

Compound 4, concentration for 50% growth inhibition: 22000 nM
The estimate for compound 4 lay 1.1-fold (0.04 log units) below the measured number, within the range that was stated.
By their numbers in this assay, from the lowest: compound 1; then compounds 2, 3 and 4 (each within the scatter of the next).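

In this assay, bromo in place of methyl on this aromatic carbon gave no change at the digits printed from compound 3 to compound 4 (within the scatter) and bromo in place of hydrogen gave a 1.2-fold higher number from compound 2 to compound 4 (0.06 log units; within the scatter) in the comparison with the unsubstituted compound. Where the earlier compounds offered only the single step from hydrogen to methyl, this place now carries three different substituents, hydrogen, methyl and bromo, with all their values within the scatter of one another, so the flat result is not particular to methyl. No measurement at hand bears on the reason for this flat result.

On these data alone, whether an amine, a carboxylic acid or a longer chain on this aromatic carbon would shift the number remains open. Also open, as far as these compounds go, is whether the other aromatic carbons of this ring would respond in the same way.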